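Chloro for trifluoromethyl on the distal ring of compound 3

The source may hold more compounds than are shown below. What is called first, only, known or untested is meant among the compounds shown, and "the series" means these compounds.

Within the three measured members of this series, compound 3 `COc1cc2cc(Oc3ccc(NC(=O)Nc4ccc(Cl)c(C(F)(F)F)c4)cc3)c(C)nc2cc1OC` holds the lowest number in a functional assay on RXF 393 cells (Homo sapiens) for inhibition, read by sulforhodamine B assay, with a stated time of 48 h, tested at 10 uM (on this read-out higher numbers stand for a weaker effect at the one concentration tested and lower numbers for a stronger effect), giving -33.4%. Compound 2 `COc1cc2cc(Oc3ccc(NC(=O)Nc4ccc(C(F)(F)F)cc4)cc3)c(C)nc2cc1OC` gives 6.29%, and compound 1 `COc1cc2cc(Oc3ccc(NC(=O)Nc4ccccc4)cc3)c(C)nc2cc1OC` gives 76.7%; both stand above compound 3 by steps beyond the scatter.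

Compound 4 `COc1cc2cc(Oc3ccc(NC(=O)Nc4ccc(Cl)c(Cl)c4)cc3)c(C)nc2cc1OC` differs from compound 3 in one place: chloro in place of trifluoromethyl on an aromatic carbon. The group enters on an aromatic carbon of a six-membered aromatic ring of carbon only, ortho to a chloro group and meta to a large group.

Among the measured compounds shown here, no measured pair swaps chloro for trifluoromethyl directly. For the measured compounds named here, the steps that bear on it concern the same ring: a number 70.4 percentage points lower from compound 1 to compound 2 (beyond the scatter) and a number 39.7 percentage points lower from compound 2 to compound 3 (beyond the scatter) show that substitution on this ring drives the read-out strongly downward, and a number 110.1 percentage points lower from compound 1 to compound 3 (beyond the scatter) gives the combined effect. The step to compound 4 removes one of the two groups that carried that gain and replaces it with a smaller one, so some loss of effect is expected, though the ring remains disubstituted.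

Going by the values given here, for compound 4 the read-out is expected to rise moderately, the step of a number 21.4 percentage points higher from compound 3 to compound 4 (beyond the scatter) being within the size of the earlier steps. Compound 4 is estimated at -12%, with a range from -45% to 20%.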

Compound 4, a percentage reported as activity, at one concentration (the size of the read-out at that concentration, not a potency): 22.3%
The estimate for compound 4 lay 34.3 percentage points below the measured number; measured number above the stated range.
By their numbers in this assay, from the lowest: compound 3; then compound 2; then compound 4; then compound 1.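

In this assay, chloro does not stand in for trifluoromethyl at this place on the distal ring: the change gives a number 55.7 percentage points higher from compound 3 to compound 4 (beyond the scatter), so the low number of compound 3 depends on which group sits there and not merely on the ring carrying two groups. Among the compounds shown here, the 3,4-dichlorophenyl ring keeps part of the gain over plain phenyl, with a number 54.4 percentage points lower from compound 1 to compound 4 (beyond the scatter), yet it falls short of the single group of 4-(trifluoromethyl)phenyl, with a number 16 percentage points higher from compound 2 to compound 4 (beyond the scatter), so a second ring substituent lowers the number in compound 3 but not in compound 4. The data shown offer no measurement that accounts for the size of these steps.

Open, going by these compounds, is how a nitrile, a methoxy group or a dimethylamino group at this same place would compare with trifluoromethyl and chloro, which would show whether trifluoromethyl is unusual here or chloro is the poor fit. Also open, on these data alone, is whether this order of compounds holds at other concentrations or in other cell lines, as all four numbers come from one concentration in one cell line.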